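Replacing the Aryl Arm with a Methyl Group

A few compounds are considered here, and "the series" means these few. Any claim that something is new, unique, unknown or untested is made for them only; others in the source may bear on it.

Measured so far in a functional assay on HeLa cells (Homo sapiens) for cytotoxicity, read by MTT assay, with a stated time of 48 h; a higher number here means a weaker inhibitor, a lower number a stronger inhibitor:
compound 1 `Cc1nc2c3ccccc3ccc2c2nc3c(ccc4ccccc43)c(-c3cccnc3)c12` gives 3860 nM
compound 2 `Cc1nc2c3ccccc3ccc2c2nc3c(ccc4ccccc43)c(-c3cc([N+](=O)[O-])ccc3N)c12` gives 5770 nM
compound 3 `Cc1nc2c3ccccc3ccc2c2nc3c(ccc4ccccc43)c(-c3ccc(O)cc3)c12` gives 4630 nM

All three share one core and differ only in the group on a single aromatic carbon. Compound 3 holds the second highest number of the three; its nearest neighbour is compound 1, with the step of a 1.2-fold higher number from compound 1 to compound 3 (0.08 log units; within the scatter), and its furthest is compound 2, with the step of a 1.2-fold lower number from compound 2 to compound 3 (0.10 log units; within the scatter). Every step between them, including a 1.5-fold higher number from compound 1 to compound 2 (0.17 log units; within the scatter), stays within the scatter, so the three aryl groups are indistinguishable on these numbers.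

Compound 4 `Cc1nc2c3ccccc3ccc2c2nc3c(ccc4ccccc43)c(C)c12` takes a different route: methyl in place of 4-hydroxyphenyl on an aromatic carbon. Going by the values given here, no measured step removes an aromatic ring from this position; the measured steps only exchange one ring for another. The expectation therefore rests on the absence of any shift among the aryl variants, and the estimated step is a 1.2-fold higher number from compound 3 to compound 4 (0.07 log units; within the scatter), not clearly beyond the scatter. Compound 4 is thus expected to give about 5500 nM in this assay, within a range from 2200 nM to 16000 nM.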

Compound 4, half-maximal inhibitory concentration: > 80000 nM
Compound 4 ended at the assay's limit; the forecaster's own chance of this, stated with the estimate: 8%; middle value at least 14-fold (1.16 log units) from the limit.
By their numbers in this assay, from the lowest: compounds 1, 3 and 2 (each within the scatter of the next). At a limit, above all of these: compound 4.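

In this assay, the aryl groups could not be told apart, but this position does not accept every group: methyl gives an at least 17-fold higher number from compound 3 to compound 4 (1.23 log units; beyond the scatter), as well as an at least 13-fold higher number from compound 2 to compound 4 (1.14 log units; beyond the scatter) and an at least 20-fold higher number from compound 1 to compound 4 (1.31 log units; beyond the scatter). Exchanging one ring for another had hidden this, since pyridin-3-yl, 2-amino-5-nitrophenyl and 4-hydroxyphenyl all place an aromatic ring on this carbon, whereas methyl has no ring. Compound 4 stands at a limit of the assay and not at a measured number, so each of these steps gives only a minimum size: the limit of > 80000 nM in this assay, at which 1 of the 4 values shown sits.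

The compounds shown leave open whether an aromatic ring is specifically required or any group larger than methyl would serve. A cyclohexyl ring or a longer chain such as n-butyl on this carbon would help separate those two possibilities.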